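Benzamide ether series: propyl to isopropyl on the aryl ring

The source may report more compounds than this note shows. Statements on the series, on what has been measured and on what is new or still open speak of the compounds shown alone.

Measured so far:
compound 1 `Nc1ccccc1NC(=O)/C=C/c1ccc(CN2CCc3ccccc32)cc1` — > 32000 nM
compound 2 `CCCc1ccc(OCc2ccc(C(=O)Nc3ccccc3N)cc2)cc1` — 4420 nM

In a functional assay on MGC-803 cells (Homo sapiens) for antiproliferative activity, read by CCK-8 assay, with a stated time of 72 h (a higher number here means a weaker inhibitor, a lower number a stronger inhibitor), compound 1 gives > 32000 nM, which is a limit of the assay and not a number. Among the compounds with values here, compound 2 in this assay gives 4420 nM, the only actual number in the set so far. The remaining value is the limit of > 32000 nM in this assay, at which 1 of the 2 values shown sits. Within the data shown here, with a limit on one side and a single number on the other, no step between measured compounds can be sized, and compound 2 stands alone as the reference point.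

Compound 3 `CC(C)c1ccc(OCc2ccc(C(=O)Nc3ccccc3N)cc2)cc1` is not yet measured. Compared with compound 2 the difference is isopropyl in place of propyl on an aromatic carbon. The two compounds have the same atoms joined differently; the chain is simply branched rather than straight at the same place on the ring.

For a change of this kind, with nothing added or removed, no step beyond the usual scatter is expected in this assay. The estimated step from compound 2 to compound 3 is a 1.0-fold higher number from compound 2 to compound 3 (0.01 log units; within the scatter). Compound 3 is therefore expected to give about 4500 nM, within a range of 2000 nM to 10000 nM.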

Compound 3, half-maximal inhibitory concentration: > 32000 nM
Compound 3 ended at the assay's limit; the forecaster's own chance of this, stated with the estimate: 3%; middle value at least 7.1-fold (0.85 log units) from the limit.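

In this assay, within the data shown here, the first readable step comes from a change that adds and removes nothing, only branching the chain at the same place, para to a large group: an at least 7.2-fold higher number from compound 2 to compound 3 (0.85 log units; beyond the scatter). The value of compound 3, > 32000 nM, is a limit of the assay and not a number, so this step has a floor but no measured size. Going from 4-propylphenyl to 4-isopropylphenyl therefore shows that this position on the aromatic ring is not indifferent to the shape of a chain of the same atoms, and compound 2 remains the only compound in the set with an actual number: the limit of > 32000 nM in this assay, at which 2 of the 3 values shown sit.

One pair cannot separate the effect of branching in general from something specific to isopropyl, nor show how far the straight chain can vary. A shorter ethyl chain, a longer butyl chain, a cyclopropyl group or an amine at this place on the ring would show whether the propyl result is an isolated case or part of a broader trend.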